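Ring-nitrogen substituent variation on a weakly binding amide series

A few compounds are considered here, and "the series" means these few. Any claim that something is new, unique, unknown or untested is made for them only; others in the source may bear on it.

Two amides on a shared core have been measured in an assay on CHO cells for displacement of a labelled ligand from adenosine receptor A3 (Homo sapiens), read by scintillation counting, with a stated time of 3 h; on this read-out higher numbers stand for weaker inhibition and lower numbers for stronger inhibition. Compound 1 `Cc1ccc(C(=O)Nc2nc(Cl)c3cn(C)nc3n2)cc1` gives 13500 nM and compound 2 `Cn1cc2c(Cl)nc(NC(=O)c3ccc(C(F)(F)F)cc3)nc2n1` gives 33500 nM. Within the data shown here, the only step recorded so far, a 2.5-fold higher number from compound 1 to compound 2 (0.39 log units; beyond the scatter), concerns the aryl amide side of the molecule. Compound 2 therefore stands with the higher of the two numbers, and compound 1 is the nearest point of comparison.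

Compound 3 `CC(C)n1cc2c(Cl)nc(NC(=O)c3ccc(C(F)(F)F)cc3)nc2n1` differs from compound 2 by isopropyl in place of methyl on an aromatic nitrogen. Among the measured compounds shown here, no measured step touches this ring nitrogen, so the recorded step from compound 1 to compound 2 does not bear on it directly; it only shows how modest the variation across this pair has been. The expectation for compound 3 in this assay is therefore a step of a 1.1-fold lower number from compound 2 to compound 3 (0.05 log units; within the scatter) that stays within the scatter. Compound 3 is estimated at 30000 nM, with a range from 12000 nM to 80000 nM.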

Compound 3, inhibition constant: 10300 nM
Compound 3: middle estimate off by 2.9-fold (0.46 log units), on the high side, outside the stated range (below it).
By their numbers in this assay, from the lowest: compounds 3 and 1 (each within the scatter of the next); then compound 2.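

The ring nitrogen is not a silent position: isopropyl in place of methyl on this aromatic nitrogen gives a 3.3-fold lower number from compound 2 to compound 3 (0.51 log units; beyond the scatter) in this assay, with the trifluoromethyl amide held constant. Among these compounds, this is the first reading at this place, and it shows that going from 1 carbon to 3 carbon in this substituent moves the number towards stronger inhibition, on this single pair only. Nothing available here accounts for the size or direction of this step.

Open, as far as these compounds go, is whether ethyl, cyclopropyl, a longer chain such as n-butyl or a bare ring nitrogen carrying hydrogen would continue or reverse this step. Also open, from the compounds shown here alone, is whether isopropyl gives a similar step when paired with the methyl-bearing aryl amide of compound 1.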